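This account rests on a few compounds, and the source may have more. Where it says the series, first, only, none or still open, it means among the compounds named here.

- Compound 1 `CC(=O)OC1C(CF)OC(n2c(Cl)nc3cc(Cl)c(Cl)cc32)C1OC(C)=O`: 100000 nM
- Compound 2 `CC(=O)OC1C(CCl)OC(n2c(Cl)nc3cc(Cl)c(Cl)cc32)C1OC(C)=O`: 90000 nM
- Compound 3 `CC(=O)OC1C(CBr)OC(n2c(Cl)nc3cc(Cl)c(Cl)cc32)C1OC(C)=O`: 60000 nM

These three values all come from a functional assay on KB cells (Homo sapiens) for inhibition; a lower number here means a stronger inhibitor, a higher number a weaker inhibitor. At 60000 nM, compound 3 cannot be told apart from the other two, as its gaps to both lie within the usual scatter of this kind of measurement.

The compound still to be measured is compound 4 `CC(=O)OC1C(CI)OC(n2c(Cl)nc3cc(Cl)c(Cl)cc32)C1OC(C)=O`. It differs from compound 3 in a single group: iodo in place of bromo on a saturated chain carbon bound to a saturated ring carbon. In words, this is iodo in place of bromo on a saturated chain carbon bound to a saturated ring carbon.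

Three measured changes at that same place bear on this one: a 1.1-fold lower number from compound 1 to compound 2 (0.05 log units; within the scatter), a 1.7-fold lower number from compound 1 to compound 3 (0.22 log units; within the scatter) and a 1.5-fold lower number from compound 2 to compound 3 (0.18 log units; within the scatter). All three are small, so no step beyond the scatter is expected in this assay. The expected step is a 1.1-fold lower number from compound 3 to compound 4 (0.04 log units; within the scatter). The estimate for compound 4 is 55000 nM, with an expected range from 25000 nM to 100000 nM.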

Compound 4, half-maximal inhibitory concentration: 60000 nM
Estimate against measurement, compound 4: 1.1-fold (0.04 log units) below; low and high end bracket the measured number.
By their numbers in this assay, from the lowest: compounds 3, 4, 2 and 1 (each within the scatter of the next).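

Putting iodo on this saturated chain carbon bound to a saturated ring carbon completes a set of four halogens in this assay and gives no change at the digits printed from compound 3 to compound 4 (within the scatter) and a 1.5-fold lower number from compound 2 to compound 4 (0.18 log units; within the scatter) and a 1.7-fold lower number from compound 1 to compound 4 (0.22 log units; within the scatter). Every one of these steps lies within the scatter, so fluoro, chloro, bromo and iodo cannot be told apart at this place, and the choice among these four halogens has no measurable effect on the read-out. No supporting data are available to explain this result.

As far as these compounds go, all four compounds carry a halogen here, so what a hydroxyl, an amine or a longer chain would do at this place remains open. All four also keep the same shared core and both acetate groups, so whether this lack of difference would hold with other groups at those places is also unknown.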